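The source may report more compounds than this note shows. Statements on the series, on what has been measured and on what is new or still open speak of the compounds shown alone.

Among the compounds with values here, only two compounds of this family have numbers so far in a functional assay on the whole organism for inhibition, with Mus musculus as the target; on this read-out higher numbers stand for an effect only at larger amounts of compound and lower numbers for an effect already at smaller amounts. There, compound 1 `Cc1ccc(C2CN(C)Cc3c(N)cccc32)cc1` gives about 1.2 mg/kg, while compound 2 `CCCCNC(=O)Nc1cccc2c1CN(C)CC2c1ccc(Cl)cc1` gives 15 mg/kg. Compound 2 therefore has the higher of the two numbers, and its gap to compound 1 lies beyond the scatter. Compound 3 `CCCCNC(=O)Nc1cccc2c1CN(C)CC2c1ccc(C)cc1` has not yet been measured. It differs from compound 2 in a single place: methyl in place of chloro on an aromatic carbon. Put simply, 4-chlorophenyl becomes 4-methylphenyl. Within the data shown here, no measured pair shows this change alone, since compound 1 also differs from compound 2 elsewhere on the core. The swap exchanges only one heavy atom for another, so the expected step of a 1.3-fold lower number from compound 2 to compound 3 (0.10 log units; within the scatter) stays within the scatter, in neither direction. For compound 3 the estimated dose is 12 mg/kg, with an expected range from 4.5 mg/kg to 30 mg/kg.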

Compound 3, dose for half-maximal effect: about 15 mg/kg
Beside the measured number, compound 3's estimate is 1.3-fold (0.10 log units) below it, within the range that was stated.
By their numbers in this assay, from the lowest: compound 1; then compounds 2 and 3 (each within the scatter of the next).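

In this assay, the swap of 4-chlorophenyl for 4-methylphenyl gives no change at the digits printed from compound 2 to compound 3 (within the scatter), so on this read-out the two groups cannot be told apart at this position of the butylcarbamoyl series. The gap between the two earlier compounds could not be tied to one place, but a single swap, butylcarbamoyl in place of hydrogen on a nitrogen on an aromatic ring, now carries a 13-fold higher number from compound 1 to compound 3 (1.10 log units; beyond the scatter), a large step towards needing more compound for the effect. Nothing available explains either result.

From the compounds shown here alone, only chloro and methyl have been compared at the position on this aromatic ring, so a methoxy group, a trifluoromethyl group or an amine there remains open. Going by these compounds, it is also open how a shorter chain than butyl, or a carboxylic acid at the chain's end, would read.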